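This account rests on a few compounds, and the source may have more. Where it says the series, first, only, none or still open, it means among the compounds named here.

Working notes on the series. In an assay on HEK293 cells for displacement of a labelled ligand from metabotropic glutamate receptor 5 (Rattus norvegicus) (on this read-out lower numbers stand for stronger inhibition and higher numbers for weaker inhibition), compound 1 `O=C(Nc1cc(-c2ccccc2)nn1-c1ccccc1)c1ccccc1` gives 4180 nM. Compound 3 `COc1cccc(-c2cc(NC(=O)c3ccccc3)n(-c3ccccc3)n2)c1` gives 3200 nM in this assay, and compound 1 holds the higher of the two plain numbers, with compound 3 nearest: a 1.3-fold lower number from compound 1 to compound 3 (0.12 log units; within the scatter), the change being methoxy in place of hydrogen on an aromatic carbon. In this assay compound 2 `COc1cc(OC)cc(C(=O)Nc2cc(-c3ccccc3)nn2-c2ccccc2)c1` returns only a limit, > 10000 nM. The step of an at least 2.3-fold higher number from compound 1 to compound 2 (0.37 log units; beyond the scatter) is 3,5-dimethoxyphenyl in place of phenyl on a carbonyl carbon, and its size is bounded only by the limit of > 10000 nM in this assay, at which 1 of the 3 values shown sits.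

Compound 4 `O=C(Nc1cc(-c2ccccc2)nn1-c1ccccn1)c1ccccc1` is still to be measured in this assay. The change is pyridin-2-yl in place of phenyl on an aromatic nitrogen. Neither measured step touches the phenyl on the aromatic nitrogen: one alters the group on the carbonyl carbon, the other adds methoxy on an aromatic carbon, and that one stays within the scatter. No step beyond the scatter is therefore expected in this assay for compound 4, with the wide range reflecting the absence of a matching measured step. Compound 4 is estimated at 4000 nM, between 1500 nM and 12000 nM, an expected step of a 1.0-fold lower number from compound 1 to compound 4 (0.02 log units; within the scatter).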

Compound 4, inhibition constant: > 10000 nM
Compound 4 gave a limit, no number; the forecaster's own chance of this, stated with the estimate: 20%; middle value at least 2.5-fold (0.39 log units) from the limit.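

The phenyl on the aromatic nitrogen now has a measured step of its own in this assay, and it is the second change beyond the scatter, at a different place from the first: an at least 2.3-fold higher number from compound 1 to compound 4 (0.37 log units; beyond the scatter). The swap leaves the heavy atom count of the group unchanged and brings in one ring nitrogen and a hydrogen-bond acceptor, yet compound 4 gives > 10000 nM, which is a limit and not a number. The series now has a second compound at this limit, with compound 2 changed on the carbonyl carbon and compound 4 changed on the aromatic nitrogen: the limit of > 10000 nM in this assay, at which 2 of the 4 values shown sit.

The compounds shown leave open how pyridin-3-yl, pyridin-4-yl or cyclohexyl on that aromatic nitrogen would read out, and so whether the step follows the ring nitrogen itself or its placement. They also leave open whether any group at this place gives a lower number than compound 1.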